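Replacing the Oxetanyl Carbamate of Compound 2 with a Fluoroalkyl Ketone

The source may hold more compounds than are shown below. What is called first, only, known or untested is meant among the compounds shown, and "the series" means these compounds.

Measured so far:
Compound 1, `Cc1nc(S(C)(=O)=O)ccc1Oc1ncnc(OC2CCN(C(=O)OC(C)(C)CF)CC2)c1F`: 138 nM
Compound 2, `Cc1nc(S(C)(=O)=O)ccc1Oc1ncnc(OC2CCN(C(=O)OC3COC3)CC2)c1F`: 2500 nM
Compound 3, `Cc1nc(S(C)(=O)=O)ccc1Oc1ncnc(OC2CCN(C(=O)SC(C)C)CC2)c1F`: 41.3 nM

These three compounds share one core and have been tested in a functional assay on isolated protein for inhibition of Glucose-dependent insulinotropic receptor (Rattus norvegicus), read by HTRF and cAMP accumulation; on this read-out lower numbers stand for an effect already at smaller amounts and higher numbers for an effect only at larger amounts of compound. Compound 2 stands highest of the three numbers. The two measured steps that connect it to the others are an 18-fold higher number from compound 1 to compound 2 (1.26 log units; beyond the scatter), read here in reverse, and a 61-fold lower number from compound 2 to compound 3 (1.78 log units; beyond the scatter); the remaining step, a 3.3-fold lower number from compound 1 to compound 3 (0.52 log units; beyond the scatter), separates the other two compounds from each other.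

Compound 4, `Cc1nc(S(C)(=O)=O)ccc1Oc1ncnc(OC2CCN(C(=O)C(C)(C)F)CC2)c1F`, is not yet measured. It differs from compound 2 in one place: 1-fluoro-1-methylethyl in place of (oxetan-3-yl)oxy on a carbonyl carbon. Both steps that start from compound 2 bear on this change, since each of them also takes the oxetane-containing group away from the carbonyl carbon, and both were large and downward. The change to compound 4 goes further in the same sense, removing the ring and the linking oxygen together and bringing in the 1-fluoro-1-methylethyl group directly on the carbonyl carbon. A large downward step in this assay is therefore expected, of about a 31-fold lower number from compound 2 to compound 4 (1.49 log units; beyond the scatter). Compound 4 is estimated to give around 80 nM, with a range from 25 nM to 250 nM.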

Compound 4, half-maximal effective concentration: 296 nM
For compound 4 the middle estimate is 3.7-fold (0.57 log units) below the measured one; the whole stated range lies below it.
By their numbers in this assay, from the lowest: compound 3; then compound 1; then compound 4; then compound 2.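

In this assay, the result shows that this carbonyl carbon does not need a linking oxygen or sulfur: with 1-fluoro-1-methylethyl attached directly, the change away from (oxetan-3-yl)oxy gives an 8.4-fold lower number from compound 2 to compound 4 (0.93 log units; beyond the scatter). That gain is only part of what the linked groups reach, as the direct attachment still falls short of the fluorinated carbamate, with a 2.1-fold higher number from compound 1 to compound 4 (0.33 log units; beyond the scatter), and further short of the isopropylsulfanyl group, with a 7.2-fold higher number from compound 3 to compound 4 (0.86 log units; beyond the scatter). The new group therefore takes an intermediate place in the series at this position, and no measurement available here accounts for that order.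

The compounds shown do not separate the effect of the linking atom from that of the group it carries, as no pair keeps one alkyl group fixed while oxygen, sulfur or a direct bond changes. From the compounds shown here alone, it also remains open how isopropyl without the fluorine, or isopropylamino with a nitrogen as the link, would read on the same carbonyl carbon.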